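This account rests on a few compounds, and the source may have more. Where it says the series, first, only, none or still open, it means among the compounds named here.

Among the measured compounds shown here, compound 2 `O=C(O)c1ccc2oc(-c3ccc(Cl)cc3)c(O)c(=O)c2c1` gives -19% in a functional assay on the whole organism (stomach) for inhibition, with Rattus norvegicus as the target, at a dose of 80 mg/kg (on this read-out higher numbers stand for more inhibition at the one dose given (going by the name of the read-out) and lower numbers for less inhibition), the lower of the two numbers measured so far; compound 1 `Cc1ccc(-c2oc3ccc(C(=O)O)cc3c(=O)c2O)cc1` gives 6%, and the step of a number 25 percentage points lower from compound 1 to compound 2 (beyond the scatter) is the only one recorded. Compound 3 `O=C(O)c1ccc2oc(-c3ccccc3Br)c(O)c(=O)c2c1` differs from compound 2 by 2-bromophenyl in place of 4-chlorophenyl on an aromatic carbon. For the measured compounds named here, no measured step exchanges one substituted phenyl group for another, so the single recorded step offers only a loose guide and no clear direction beyond the scatter. For compound 3 the expected step is a number 11 percentage points higher from compound 2 to compound 3 (beyond the scatter). Compound 3 is estimated at -8%, within a range from -35% to 20%.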

Compound 3, a percentage reported as inhibition, in the whole organism at one dose (the size of the read-out at that dose, not a potency): 22%
Beside the measured number, compound 3's estimate is 30 percentage points below it, outside the stated range (above it).
By their numbers in this assay, from the lowest: compound 2; then compound 1; then compound 3.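

Moving from 4-chlorophenyl to 2-bromophenyl at this position gives a number 41 percentage points higher from compound 2 to compound 3 (beyond the scatter), while moving from 4-methylphenyl to 2-bromophenyl gives a number 16 percentage points higher from compound 1 to compound 3 (beyond the scatter), so the choice of substituted phenyl group can shift this number substantially. Both steps change the substituent and its place on the phenyl ring at once, so their contributions cannot be separated. Nothing available explains the rise.

Still open, as far as these compounds go, is how 2-chlorophenyl and 4-bromophenyl would compare, which could separate the halogen from its place. From the compounds shown here alone, the effect of an amine on that phenyl ring also remains unknown.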